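This account rests on a few compounds, and the source may have more. Where it says the series, first, only, none or still open, it means among the compounds named here.

Compound 1 `O=C(Nc1cccc([N+](=O)[O-])c1)N1CCN(S(=O)(=O)c2sccc2-c2ccccc2Oc2ccc(O)c(O)c2)CC1` gives 30% in an assay for binding affinity to Apoptosis regulator Bcl-2 (Homo sapiens), read by fluorescence polarization, with stated times of 30 min and 20 min, tested at 100 uM; a higher number here means more inhibition at the concentration tested (going by the name of the read-out), a lower number less inhibition.
Compound 2 `O=C(Nc1ccc(F)cc1)N1CCN(S(=O)(=O)c2sccc2-c2ccccc2Oc2ccc(O)c(O)c2)CC1` gives 33%.
Compound 3 `COc1ccc(Oc2ccccc2-c2ccsc2S(=O)(=O)N2CCN(C(=O)Nc3ccc([N+](=O)[O-])cc3)CC2)cc1OC` gives 17%.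

Compound 3 stands lowest of the three, with compound 1 beyond the scatter above it and compound 2 further still. Compound 4 `O=C(Nc1ccc([N+](=O)[O-])cc1)N1CCN(S(=O)(=O)c2sccc2-c2ccccc2Oc2ccc(O)c(O)c2)CC1` differs from compound 3 in one place: 3,4-dihydroxyphenyl in place of 3,4-dimethoxyphenyl on an oxygen on an aromatic ring. Among the measured compounds shown here, no measured pair differs in this place alone; the one measured step, a number 3 percentage points higher from compound 1 to compound 2 (within the scatter), concerns the group on the amide-type nitrogen and lies within the scatter. Compounds 1 and 2, which carry 3,4-dihydroxyphenyl, both read well above compound 3, which carries 3,4-dimethoxyphenyl, though each also differs from compound 3 elsewhere. On that basis compound 4 is expected to move upward by about a number 13 percentage points higher from compound 3 to compound 4 (beyond the scatter). The estimate for compound 4 is 30%, with a range from 18% to 42%.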

Compound 4, a percentage reported as inhibition, at one concentration (the size of the read-out at that concentration, not a potency): 33%
Compound 4: middle estimate off by 3 percentage points, on the low side; low and high end bracket the measured number.
By their numbers in this assay, from the lowest: compound 3; then compounds 1, 2 and 4 (each within the scatter of the next).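

Taken alone, 3,4-dihydroxyphenyl in place of 3,4-dimethoxyphenyl on an oxygen on an aromatic ring gives a number 16 percentage points higher from compound 3 to compound 4 (beyond the scatter) in this assay with the rest of the structure unchanged, so this position now has a direct reading. Among the compounds shown here, the group on the amide-type nitrogen shows no such step, with no change at the digits printed from compound 2 to compound 4 (within the scatter) for nitro in place of fluoro and a number 3 percentage points higher from compound 1 to compound 4 (within the scatter) for 4-nitrophenyl in place of 3-nitrophenyl among the compounds carrying 3,4-dihydroxyphenyl. Nothing available accounts for the step at the oxygen-linked ring. The compounds shown leave open how a ring carrying a single hydroxyl, an amine or a carboxylic acid would read here. They also leave open whether the same step holds with another group on the amide-type nitrogen.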